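From dimethylamino to nitro on the aromatic ring

A few compounds are considered here, and "the series" means these few. Any claim that something is new, unique, unknown or untested is made for them only; others in the source may bear on it.

Measured so far in a functional assay on OVCAR-3 cells (Homo sapiens) for cytotoxicity, read by sulforhodamine B assay; a lower number here means that less compound is tolerated, a higher number that more compound is tolerated:
- compound 1 `CC1=CC[C@@H]([C@@](C)(O)CCCC(C)(C)NC=S)CC1` gives > 100000 nM (a limit)
- compound 2 `CC1=CC[C@@H]([C@@](C)(O)CCCC(C)(C)NC(=S)N/N=C\c2ccccc2)CC1` gives 43600 nM (a number)
- compound 3 `CC1=CC[C@@H]([C@@](C)(O)CCCC(C)(C)NC(=S)N/N=C\c2ccc(N(C)C)cc2)CC1` gives > 100000 nM (a limit)

Compound 3 stands at > 100000 nM and this is a limit and not a number. Within the data shown here, it shares with compound 1 the limit of > 100000 nM in this assay, at which 2 of the 3 values shown sit, and only compound 2 gives a number in this assay so far.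

The next structure is compound 4 `CC1=CC[C@@H]([C@@](C)(O)CCCC(C)(C)NC(=S)N/N=C\c2ccc([N+](=O)[O-])cc2)CC1` with nitro in place of dimethylamino on an aromatic carbon, para to a large group (nitro in place of dimethylamino on an aromatic carbon). The closer measured step, with dimethylamino in place of hydrogen on an aromatic carbon, is an at least 2.2-fold higher number from compound 2 to compound 3 (0.36 log units; beyond the scatter) and the other, which brings in the aromatic ring, is an at least 2.2-fold lower number from compound 1 to compound 2 (0.36 log units; beyond the scatter) and both are known from one side only. Compound 4 lacks the dimethylamino group, and compound 2, also without it, gives 43600 nM as the nearest number, so a modest downward step is expected. Among the measured compounds shown here, no measured step shows what nitro itself does, and a return to the limit remains possible. The expected change is an at least 2.0-fold lower number from compound 3 to compound 4 (0.30 log units; that floor lies within the scatter) and it is an estimate only. Compound 4 is estimated at 50000 nM (expected range 18000 nM to 120000 nM).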

Compound 4, concentration lethal to 50% of the cells: > 100000 nM
Compound 4: a limit, no number; the forecaster's own chance of this, stated with the estimate: 35%; at least 2.0-fold (0.30 log units) between middle value and limit.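

In this assay compound 4 gives > 100000 nM, which is a limit and not a number. Nitro in place of hydrogen on an aromatic carbon gives an at least 2.2-fold higher number from compound 2 to compound 4 (0.36 log units; beyond the scatter), in the same direction as dimethylamino in place of hydrogen on that carbon, which gives an at least 2.2-fold higher number from compound 2 to compound 3 (0.36 log units; beyond the scatter), so for these two groups the direction no longer rests on dimethylamino alone. The step from dimethylamino to nitro cannot be read, and the new result adds a further compound to the series' shared limit: the limit of > 100000 nM in this assay, at which 3 of the 4 values shown sit.

Still open, from the compounds shown here alone, is whether compound 3 and compound 4 differ at all, since neither gives a number, and whether any group on this aromatic carbon keeps a number, where compound 2 gives 43600 nM as the only one so far. A fluoro, chloro, methoxy or hydroxyl group in the same place would test whether the step seen with dimethylamino and nitro extends to other groups on the ring.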